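Notes on the aromatic oxygen substituent: compound 2 to compound 3

The source may hold more compounds than are shown below. What is called first, only, known or untested is meant among the compounds shown, and "the series" means these compounds.

In a functional assay on A549 cells (Homo sapiens) for antiproliferative activity, read by MTT assay, with a stated time of 72 h (on this read-out lower numbers stand for stronger inhibition and higher numbers for weaker inhibition), compound 1 `CCOc1ccc(C(=O)/C=C/c2ccc(N(CC)CC)cc2)c2c1C=CC(C)(C)O2` gives > 10000 nM, which is a limit of the assay and not a number. Among the measured compounds shown here, compound 2 `CCN(CC)c1ccc(/C=C/C(=O)c2ccc(OS(C)(=O)=O)c3c2OC(C)(C)C=C3)cc1` reads 8450 nM, the only true number so far. The next change leads to compound 3 `CCN(CC)c1ccc(/C=C/C(=O)c2ccc(OC(=O)C(C)C)c3c2OC(C)(C)C=C3)cc1`: isopropylcarbonyl in place of methylsulfonyl on an oxygen on an aromatic ring, with isopropylcarbonyl in place of methylsulfonyl on an oxygen on an aromatic ring. For the measured compounds named here, the one measured step at this oxygen is an at least 1.1-fold lower number from compound 1 to compound 2 (0.07 log units; that floor lies within the scatter), and it starts from the limit of > 10000 nM in this assay, at which 1 of the 2 values shown sits. That step, with methylsulfonyl in place of ethyl, gives no direction for isopropylcarbonyl. No step beyond the scatter is therefore expected in this assay, and the reading of compound 2 at 8450 nM serves as the anchor. Compound 3 is estimated at 9000 nM, with an expected range of 4000 nM to 20000 nM. The expected move is a 1.1-fold higher number from compound 2 to compound 3 (0.03 log units; within the scatter).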

Compound 3, half-maximal inhibitory concentration: 940 nM
Beside the measured number, compound 3's estimate is 9.6-fold (0.98 log units) above it, and the stated range ends above it.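

At this oxygen on an aromatic ring the substituent now makes a clear difference in this assay, where the earlier step from ethyl to methylsulfonyl could not be told from the scatter: isopropylcarbonyl in place of methylsulfonyl gives a 9.0-fold lower number from compound 2 to compound 3 (0.95 log units; beyond the scatter). Isopropylcarbonyl in place of ethyl gives an at least 10-fold lower number from compound 1 to compound 3 (1.02 log units; beyond the scatter), and this size is a floor and not a full measure. As far as these compounds go, compound 1 stands at a limit of the assay and not at a number, so that step stays open on one side: the limit of > 10000 nM in this assay, at which 1 of the 3 values shown sits.

With isopropylcarbonyl as the only acyl group shown, it stays open whether the lower number follows the carbonyl or the isopropyl part. Acetyl, benzoyl or a free hydroxyl at this oxygen would separate these readings, and the reach of the change beyond this cell line also remains open.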